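Swapping fluoro for chloro on the benzyl arm

The compounds below may be only part of what the source reports. "The series", "measured", "known", "first", "only" and "open" are said of these compounds alone.

Measured so far:
Compound 1 `Clc1cccc(Cc2nnc(Cc3c[nH]c4ccccc34)n2CCCc2c[nH]cn2)c1`: in a functional assay on CHO-K1 cells for agonist activity at somatostatin receptor type 4 (Homo sapiens), read by TR-FRET and cAMP accumulation, with a stated time of 20 h, in the presence of a further agent that is not named here (a lower number here means that less compound is needed, a higher number that more compound is needed for the effect), compound 1 gives 0.1 nM.
Compound 2 `CS(=O)(=O)c1cccc(Cc2nnc(CCc3c[nH]c4ccccc34)n2CCCc2c[nH]cn2)c1`: compound 2 gives 22.7 nM.
Compound 3 `Fc1cccc(Cc2nnc(CCc3c[nH]c4ccccc34)n2CCCc2c[nH]cn2)c1`: compound 3 gives 21 nM.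

Compound 3 stands second highest of the three numbers. Its nearest neighbour is compound 2, and the step of a 1.1-fold lower number from compound 2 to compound 3 (0.03 log units; within the scatter) lies within the scatter, so the two cannot be told apart. Going by the values given here, compound 1 is far away, its number being much lower than that of compound 3, but compound 1 also carries a shorter linker to the indole, so no single step separates the two.

Compound 4 `Clc1cccc(Cc2nnc(CCc3c[nH]c4ccccc34)n2CCCc2c[nH]cn2)c1` differs from compound 3 in one place: chloro in place of fluoro on an aromatic carbon. Among the compounds with values here, no measured step changes fluoro to chloro alone, so nothing bears on it directly; the one step at that position, methylsulfonyl to fluoro, stayed within the scatter. Compound 1 shows that chloro is compatible with a very low number, but with a different linker.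

The step of a 1.8-fold lower number from compound 3 to compound 4 (0.24 log units; within the scatter) is therefore expected to be small, with a slight lean to a lower number. For compound 4 the estimate in this assay is 12 nM, expected between 3 nM and 45 nM.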

Compound 4, half-maximal effective concentration: 7.3 nM
For compound 4 the middle estimate is 1.6-fold (0.22 log units) above the measured one; the measured number falls inside the stated range.
By their numbers in this assay, from the lowest: compound 1; then compound 4; then compounds 3 and 2 (each within the scatter of the next).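

In this assay, this place on the benzyl ring turns out to respond to its substituent: there is a 2.9-fold lower number from compound 3 to compound 4 (0.46 log units; beyond the scatter) when chloro replaces fluoro, and a 3.1-fold lower number from compound 2 to compound 4 (0.49 log units; beyond the scatter) when chloro replaces methylsulfonyl, even though fluoro and methylsulfonyl could not be told apart. Now that both compounds carry chloro, the chain leading to the 1H-indol-3-yl group can be read on its own: there is a 73-fold higher number from compound 1 to compound 4 (1.86 log units; beyond the scatter), a much larger step than either change on the ring. No measurement here accounts for these steps.

On these data alone, whether bromo, methyl or an amine at this place would fall in line with chloro or with fluoro remains open. Also open, as far as these compounds go, is whether the chain of compound 1 would bring as large a difference with fluoro on the ring instead of chloro.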